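The source may hold more compounds than are shown below. What is called first, only, known or untested is meant among the compounds shown, and "the series" means these compounds.

Measured in a functional assay on MCF7 cells (Homo sapiens) for inhibition, read by luminescence, with a stated time of 6 days; on this read-out higher numbers stand for weaker inhibition and lower numbers for stronger inhibition:
- compound 1 `CC(F)(F)c1cc(Cl)ccc1-c1sc2cc(C(=O)O)ccc2c1Oc1ccc(OC2CN(CCCF)C2)cc1`: 34.7 nM
- compound 2 `CC(F)(F)c1cc(Cl)ccc1-c1sc2cc(C(=O)O)ccc2c1Oc1ccc(O[C@@H]2CCN(CCCF)C2)cc1`: 4.2 nM

Of these two, compound 2 stands lowest at 4.2 nM. Compound 3 `CC(F)(F)c1cc(Cl)ccc1-c1sc2cc(C(=O)O)ccc2c1Oc1ccc(NC2CN(CCCF)C2)cc1`, not yet measured, differs from compound 2 as follows: a group of 9 heavy atoms (6 carbon, 2 nitrogen, 1 fluorine; one four-membered non-aromatic ring with 1 hetero atom) in place of a group of 10 heavy atoms (7 carbon, 1 nitrogen, 1 oxygen, 1 fluorine; one five-membered non-aromatic ring with 1 hetero atom), on an aromatic carbon. The change sits on an aromatic carbon of a six-membered aromatic ring of carbon only, para to a large group.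

For the measured compounds named here, one measured step bears on it: an 8.3-fold lower number from compound 1 to compound 2 (0.92 log units; beyond the scatter). That step went from a four-membered to a five-membered non-aromatic ring, and compound 3 returns to the four-membered ring. Reversing the step named in an 8.3-fold lower number from compound 1 to compound 2 (0.92 log units; beyond the scatter) leads to the expectation of a higher number in this assay. Going by the values given here, no measured pair shows the effect of the second nitrogen replacing the oxygen, so the range is kept wide.

The expected change is a 4.3-fold higher number from compound 2 to compound 3 (0.63 log units; beyond the scatter). For compound 3 the estimate is 18 nM, with an expected range of 4 nM to 70 nM.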

Compound 3, half-maximal inhibitory concentration: 5.9 nM
Compound 3: middle estimate off by 3.1-fold (0.48 log units), on the high side; the range from low to high includes it.
By their numbers in this assay, from the lowest: compounds 2 and 3 (each within the scatter of the next); then compound 1.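

In this assay the four-membered ring proves compatible with a low number once an amine nitrogen replaces the oxygen on the aromatic carbon, as shown by a 5.9-fold lower number from compound 1 to compound 3 (0.77 log units; beyond the scatter) for this single exchange. The earlier step between the two rings had left that open, and the comparison with the five-membered ring now reads as a 1.4-fold higher number from compound 2 to compound 3 (0.15 log units; within the scatter) and gives no separation between these two groups. No measurement at hand accounts for what the nitrogen does here.

Going by these compounds, it remains open whether the same amine nitrogen would shift the number on the five-membered ring as it does on the four-membered one. On these data alone, it is equally open whether a methyl group on that nitrogen, which takes the place of its hydrogen, would keep the number of compound 3 in this range.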